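Methoxy in Place of Nitro, Tried a Second Time

A few compounds are considered here, and "the series" means these few. Any claim that something is new, unique, unknown or untested is made for them only; others in the source may bear on it.

Of the compounds shown here, three sharing an aminothiophene-ketone-like arrangement have been measured in a functional assay on CHO cells for agonist activity at adenosine receptor A1 (Homo sapiens), read by fluorescence and ERK phosphorylation, with stated times of 30 min and 1.5 h, tested at 10 uM; on this read-out lower numbers stand for a weaker effect and higher numbers for a stronger effect at the one concentration tested. Compound 1 `Nc1scc(-c2cccc([N+](=O)[O-])c2)c1C(=O)c1ccccc1` gives 50%. Compound 2 `COc1cccc(-c2csc(N)c2C(=O)c2ccccc2)c1` gives 34%; it differs from compound 1 in one place, (methoxy in place of nitro on an aromatic carbon), and this single change brought a number 16 percentage points lower from compound 1 to compound 2 (beyond the scatter). Compound 3 `Nc1scc(-c2ccc([N+](=O)[O-])cc2)c1C(=O)c1ccc(Cl)cc1` gives 52%; how its core differs from the core of compound 1 is not broken down here, and its value and that of compound 1 sit within the usual scatter of each other, so nothing separates them.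

Compound 4 `COc1ccc(-c2csc(N)c2C(=O)c2ccc(Cl)cc2)cc1` has not yet been measured. Relative to compound 3 it carries methoxy in place of nitro on an aromatic carbon. For the measured compounds named here, this is the same kind of change as the one from compound 1 to compound 2, but not the same: in compound 2 the methoxy stands meta to a large group, whereas in compound 4 it stands para to a large group. Going by the values given here, the one earlier example is therefore only a guide. On that guide the change is expected to amount to a number 16 percentage points lower from compound 3 to compound 4 (beyond the scatter). Among the compounds with values here, compound 4 is accordingly estimated to give 36%, with a likely range from 22% to 50%, because a number 16 percentage points lower from compound 1 to compound 2 (beyond the scatter) is the only precedent and compound 3 starts from 52%. Whether the shift in place widens or narrows the step cannot be told from these compounds alone.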

Compound 4, a percentage reported as activity, at one concentration (the size of the read-out at that concentration, not a potency): 55%
Compound 4: middle estimate off by 19 percentage points, on the low side; the whole stated range lies below it.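

In this assay putting methoxy in place of nitro brought a number 3 percentage points higher from compound 3 to compound 4 (within the scatter), so on this core the change leaves nothing that separates the two compounds. The swap therefore does not carry a fixed step from one core to another in this series, and the earlier drop cannot simply be transferred: the same change on two cores in this assay, a number 16 percentage points lower (beyond the scatter) from compound 1 to compound 2 and a number 3 percentage points higher (within the scatter) from compound 3 to compound 4, 19 percentage points apart, beyond the scatter of two such steps.

What this does not show is the source of the gap, since the two pairs differ both in the rest of the core and in where the group sits, with the methoxy of compound 4 para to a large group, and two pairs cannot pull those differences apart.

The compounds shown leave open how a group such as an amine, a carboxylic acid or a longer chain would read in place of the methoxy on either core. They also leave open how nitro and methoxy compare when only the place on the ring changes while the rest of the core stays fixed, and how these compounds would compare over a range of concentrations rather than at a single one.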